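Swapping the Urea Aryl Group: Compound 2 to Compound 3

This account rests on a few compounds, and the source may have more. Where it says the series, first, only, none or still open, it means among the compounds named here.

Compound 2 `COc1cc(-c2nn(-c3cccc(NC(=O)Nc4ccc(Cl)c(Cl)c4)c3)cc2-c2ccncc2)ccc1Cl` is the stronger of the two compounds measured in a functional assay on SNB-75 cells (Homo sapiens) for inhibition, read by sulforhodamine B assay, with a stated time of 48 h; a higher number here means a weaker inhibitor of growth, a lower number a stronger inhibitor of growth: compound 2 gives 1050 nM, while compound 1 `O=C(Nc1cccc(-n2cc(-c3ccncc3)c(-c3ccc(Cl)c(O)c3)n2)c1)Nc1cccc(C(F)(F)F)c1` gives 3650 nM, a gap beyond the usual scatter. Compound 1 differs from compound 2 in more than one place, so its value cannot be tied to a single group. Compound 3 `COc1cc(-c2nn(-c3cccc(NC(=O)Nc4cccc(C(F)(F)F)c4)c3)cc2-c2ccncc2)ccc1Cl` keeps compound 2 intact except for (3-(trifluoromethyl)phenyl in place of 3,4-dichlorophenyl on an amide-type nitrogen). Among the measured compounds shown here, with no directly comparable pair to lean on, the expected step is modest, if any, and leaning toward weaker inhibition. Compound 3 is estimated at 2000 nM, within 700 nM to 6000 nM. The expected step is a 1.9-fold higher number from compound 2 to compound 3 (0.28 log units; within the scatter).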

Compound 3, concentration for 50% growth inhibition: 1160 nM
Compound 3: the middle estimate sits 1.7-fold (0.24 log units) above what was measured; the range from low to high includes it.
By their numbers in this assay, from the lowest: compounds 2 and 3 (each within the scatter of the next); then compound 1.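

In this assay, 3-(trifluoromethyl)phenyl in place of 3,4-dichlorophenyl on the amide-type nitrogen gives a 1.1-fold higher number from compound 2 to compound 3 (0.04 log units; within the scatter) and so leaves growth inhibition unchanged within the scatter at this position. Compound 3 also isolates a second change, since methyl in place of hydrogen on the oxygen on the aromatic ring gives a 3.1-fold lower number from compound 1 to compound 3 (0.50 log units; beyond the scatter) as a single-place step. Nothing measured here explains either result.

On these data alone, whether a cyclohexyl group on that nitrogen would give a similar value remains open. So does the effect of an ethyl group on that oxygen.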